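Removing the Benzyl Group from the Amide Nitrogen

The source may report more compounds than this note shows. Statements on the series, on what has been measured and on what is new or still open speak of the compounds shown alone.

In a functional assay on CHO cells for agonist activity at adenosine receptor A1 (Homo sapiens), read by ERK phosphorylation, tested at 10 uM (on this read-out higher numbers stand for a stronger effect at the one concentration tested and lower numbers for a weaker effect), compound 2 `Nc1sc2c(c1C(=O)NCc1ccccc1)CCCCCC2` gives 50%, and compound 1 `Nc1sc2c(c1C(=O)NNc1ccccc1)CCCCCC2` gives 43% in this assay; the two lie within the scatter of each other, as the step of a number 7 percentage points higher from compound 1 to compound 2 (within the scatter) shows. Compound 3 `NC(=O)c1c(N)sc2c1CCCCCC2` differs from compound 2 by hydrogen in place of benzyl on an amide-type nitrogen. For the measured compounds named here, the one step that touches this nitrogen, a number 7 percentage points higher from compound 1 to compound 2 (within the scatter), stayed within the scatter, but no measured step removes the substituent there altogether, so the bearing of that step is indirect. Compound 3 is therefore expected to give 35% in this assay, between 10% and 60%, an estimated step of a number 15 percentage points lower from compound 2 to compound 3 (beyond the scatter).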

Compound 3, a percentage reported as activity, at one concentration (the size of the read-out at that concentration, not a potency): 48%
Compound 3: the middle estimate sits 13 percentage points below what was measured, within the range that was stated.
By their numbers in this assay, from the lowest: compounds 1, 3 and 2 (each within the scatter of the next).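

The step of a number 2 percentage points lower from compound 2 to compound 3 (within the scatter) in this assay shows that the benzyl group, with its six-membered aromatic ring, can leave this amide-type nitrogen without the read-out moving beyond the scatter. The step of a number 5 percentage points higher from compound 1 to compound 3 (within the scatter) shows the same for hydrogen in place of anilino, so across these three compounds neither substituent is needed to retain the effect at the one concentration tested. Nothing at hand explains this result.

As far as these compounds go, whether a methyl group or a longer alkyl chain on this nitrogen would fit the same picture remains open. So does the effect of a carboxylic acid in place of the primary amide of compound 3.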